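Hydroxy in place of amino on compound 1

The compounds below may be only part of what the source reports. "The series", "measured", "known", "first", "only" and "open" are said of these compounds alone.

compound 1 `COc1ccc(Cc2cc(OC)c(OC)c(OC)c2)cc1N`: 3.2 nM
compound 2 `CCn1ccc2cc(Cc3ccc(OC)c(OC)c3OC)ccc21`: > 1000 nM

Among the measured compounds shown here, in a functional assay on HeLa cells (Homo sapiens) for cytotoxicity, read by XTT assay, with a stated time of 72 h (a higher number here means a weaker inhibitor, a lower number a stronger inhibitor), compound 1 gives 3.2 nM, the only exact number so far. Compound 2 gives > 1000 nM, which is a limit of the assay and not a number. Compound 3 `COc1ccc(Cc2cc(OC)c(OC)c(OC)c2)cc1O` alters compound 1 in one place: hydroxy in place of amino on an aromatic carbon. It carries hydroxy in place of amino on an aromatic carbon, ortho to a methoxy group. For the measured compounds named here, no measured pair shows this change. A modest weakening in this assay is expected, estimated as a 2.5-fold higher number from compound 1 to compound 3 (0.40 log units; beyond the scatter). For compound 3 the expected value is 8 nM, with an estimated range of 2 nM to 40 nM.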

Compound 3, half-maximal inhibitory concentration: 2.9 nM
Beside the measured number, compound 3's estimate is 2.8-fold (0.44 log units) above it; low and high end bracket the measured number.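

In this assay, among the compounds shown here, the first measured pair at this position gives a 1.1-fold lower number from compound 1 to compound 3 (0.04 log units; within the scatter) for hydroxy in place of amino, ortho to a methoxy group. The amino group of compound 1 is therefore not needed for this level of activity, since hydroxy on the same aromatic carbon serves equally well. Nothing measured here says why the two groups read alike.

On these data alone, whether this carbon would accept a group that is neither amino nor hydroxy, such as a fluorine atom, an acetamide or a carboxylic acid, remains open.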